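A Hydroxymethyl Variant Judged from Three Measured Analogues

The source may hold more compounds than are shown below. What is called first, only, known or untested is meant among the compounds shown, and "the series" means these compounds.

Three compounds share one core and were tested in an assay on CHO cells for displacement of a labelled ligand from Substance-P receptor (Homo sapiens), in the presence of a further agent that is not named here; a lower number here means a stronger inhibitor, a higher number a weaker inhibitor:

compound 1, `C[C@@H](O[C@H]1CN2C(=O)C=C(c3ccccc3)CC2[C@@H]1c1ccc(F)cc1)c1cc(C(F)(F)F)cc(C(F)(F)F)c1`, gives 89.5 nM
compound 2, `C[C@@H](O[C@H]1CN2C(=O)C=C(c3ccc(C#N)cc3)CC2[C@@H]1c1ccc(F)cc1)c1cc(C(F)(F)F)cc(C(F)(F)F)c1`, gives 53 nM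
compound 3, `C[C@@H](O[C@H]1CN2C(=O)C=C(c3ccc(F)cc3)CC2[C@@H]1c1ccc(F)cc1)c1cc(C(F)(F)F)cc(C(F)(F)F)c1`, gives 100 nM

Compound 1 sits among the other two with no separation beyond the scatter: a 1.1-fold higher number from compound 1 to compound 3 (0.05 log units; within the scatter), and a 1.7-fold lower number from compound 1 to compound 2 (0.23 log units; within the scatter). The pair of compound 2 and compound 3 likewise stays within the scatter, a 1.9-fold higher number from compound 2 to compound 3 (0.28 log units; within the scatter).

Compound 4, `C[C@@H](O[C@H]1CN2C(=O)C=C(c3ccc(CO)cc3)CC2[C@@H]1c1ccc(F)cc1)c1cc(C(F)(F)F)cc(C(F)(F)F)c1`, is not yet measured. It differs from compound 1 by hydroxymethyl in place of hydrogen on an aromatic carbon. The two steps that bear on this are the ones that place a cyano or a fluoro at the same aromatic carbon of compound 1, and neither moved this assay beyond the scatter. With only these two substitutions to go on, no step beyond the scatter is expected from the hydroxymethyl either, and the expected number for compound 4 is 80 nM, with a range of 40 nM to 160 nM, which amounts to an estimated 1.1-fold lower number from compound 1 to compound 4 (0.05 log units; within the scatter).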

Compound 4, half-maximal inhibitory concentration: 23 nM
Compound 4: middle estimate off by 3.5-fold (0.54 log units), on the high side; measured number below the stated range.
By their numbers in this assay, from the lowest: compound 4; then compounds 2, 1 and 3 (each within the scatter of the next).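

Hydroxymethyl is the first group shown at this aromatic carbon, para to a large group, to move the number in this assay beyond the scatter, with a 3.9-fold lower number from compound 1 to compound 4 (0.59 log units; beyond the scatter) while the cyano and fluoro steps from compound 1 stayed within it. The identity of the group at this carbon therefore matters, since there is also a 4.3-fold lower number from compound 3 to compound 4 (0.64 log units; beyond the scatter) for the exchange of fluoro and a 2.3-fold lower number from compound 2 to compound 4 (0.36 log units; beyond the scatter) for the exchange of cyano. Nothing measured here accounts for the advantage of hydroxymethyl over these groups.

The compounds shown leave open whether the gain depends on the hydroxyl hydrogen, the oxygen or the added carbon, which methyl and methoxymethyl at this carbon would help to separate. They also leave open how an aminomethyl group, a carboxylic acid or the longer hydroxyethyl chain would fare there.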